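Methyl for chloro on the aryl group of a bicyclic amine series

The source may hold more compounds than are shown below. What is called first, only, known or untested is meant among the compounds shown, and "the series" means these compounds.

Measured so far:
compound 1, `Clc1ccc(-c2n[nH]c3c2CCNCC3)cc1`, 94.8%
compound 2, `Clc1ccc(-c2noc3c2CCNCC3)cc1`, 94.9%

Both compounds share the same core and the same para chloro-aryl group; they differ only in the five-membered ring of the core. In a functional assay on HEK293 cells for antagonist activity at 5-hydroxytryptamine receptor 7 (Homo sapiens), read by luminescence and cAMP accumulation (on this read-out higher numbers stand for larger maximal responses and lower numbers for smaller maximal responses), compound 1 gives 94.8% and compound 2 gives 94.9%. The two numbers lie within the scatter of each other, so the data show no separation between compound 1 and compound 2; both reach near-complete maximal responses.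

Compound 3, `Cc1ccc(-c2n[nH]c3c2CCNCC3)cc1`, is still to be measured. It differs from compound 1 by methyl in place of chloro on an aromatic carbon. Among the measured compounds shown here, no measured pair in this small set shows a step for such a change, so the expectation rests only on the near-ceiling responses of compound 1 and compound 2.

The step from a number 2.8 percentage points lower from compound 1 to compound 3 (within the scatter) is expected to be small, with no direction beyond the scatter, since compound 1 already gives 94.8%. Compound 3 is therefore estimated at 92%, with a range from 78% to 102%.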

Compound 3, largest response reached (reported as Imax), in percent of the reference or control that the assay uses: 97.4%
The estimate for compound 3 lay 5.4 percentage points below the measured number; low and high end bracket the measured number.
By their numbers in this assay, from the lowest: compounds 1, 2 and 3 (each within the scatter of the next).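

In this assay, methyl in place of chloro on an aromatic carbon, para to a large group, gives a number 2.6 percentage points higher from compound 1 to compound 3 (within the scatter), so this change does not separate the two compounds. At this position of the core of compound 1, chloro and methyl, each a group of 1 heavy atom, therefore read alike, and the maximal response stays near-complete with either group. No available data bear on why the two groups read alike.

Open, on these data alone, is how the read-out responds at this aromatic carbon to groups that differ more from chloro, such as an amine, a carboxylic acid or a longer chain. Also open, as far as these compounds go, is whether methyl in place of chloro reads the same way on the core of compound 2.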